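The source may report more compounds than this note shows. Statements on the series, on what has been measured and on what is new or still open speak of the compounds shown alone.

Compound 1 `CCCCCNc1cccc2c(S(=O)(=O)Nc3onc(C)c3C)cccc12`: 80 nM
Compound 2 `Cc1noc(NS(=O)(=O)c2cccc3c(N(C)C)cccc23)c1-c1ccccc1`: 15900 nM

Of the compounds shown here, two have been measured in an assay on VSM-A10 cells for antagonist activity at Endothelin-1 receptor (Rattus norvegicus); a higher number here means a weaker inhibitor, a lower number a stronger inhibitor. Compound 1 gives 80 nM, and compound 2 gives 15900 nM, the higher of the two numbers; the gap between them lies well beyond the scatter of repeated measurements, so compound 2 is the weaker inhibitor here. Going by the values given here, no single-point step between measured compounds is available, since the two differ from each other in more than one place.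

Compound 3 `Cc1noc(NS(=O)(=O)c2cccc3c(N(C)C)cccc23)c1[N+](=O)[O-]` is the next compound to be tested. It is derived from compound 2 by a single change: nitro in place of phenyl on an aromatic carbon. Among the compounds with values here, no measured pair isolates this exact change, so the direction of the effect cannot be read from the data. Compound 1, which carries a methyl group rather than a phenyl at the corresponding place, is far more potent, but it also differs elsewhere, so its value cannot be attributed to that site alone.

For compound 3 in this assay the authors' estimate is 8000 nM, within a range of 1500 nM to 40000 nM. The expected step of a 2.0-fold lower number from compound 2 to compound 3 (0.30 log units; within the scatter) is thus a modest one, not confidently beyond the scatter.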

Compound 3, half-maximal inhibitory concentration: 17300 nM
Compound 3: the middle estimate sits 2.2-fold (0.33 log units) below what was measured, within the range that was stated.
By their numbers in this assay, from the lowest: compound 1; then compounds 2 and 3 (each within the scatter of the next).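

In this assay, going by these compounds alone, nitro in place of phenyl on this aromatic carbon gives a 1.1-fold higher number from compound 2 to compound 3 (0.04 log units; within the scatter), the first reading of a change at this position with everything else held constant. The two groups differ widely in what is counted for them: phenyl brings six heavy atoms, a six-membered aromatic ring of carbon only and no hydrogen-bond acceptors, while nitro brings three heavy atoms, no ring and two hydrogen-bond acceptors, yet this exchange does not separate compound 2 from compound 3 on the core they share. No measurement at hand bears on why these two groups read alike.

From the compounds shown here alone, whether an amine or a carboxylic acid on the same aromatic carbon would also leave the number in place remains open, since one pair cannot show how the position responds to other groups. Also open, going by these compounds, is how much of the gap between compound 1 at 80 nM and compound 2 at 15900 nM belongs to this position. Those two compounds differ in more than one place.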